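Nitro in place of the hydroxy of compound 2

The source may report more compounds than this note shows. Statements on the series, on what has been measured and on what is new or still open speak of the compounds shown alone.

In a functional assay on KB cells (Homo sapiens) for antiproliferative activity, read by MTT assay, with a stated time of 72 h (a lower number here means a stronger inhibitor, a higher number a weaker inhibitor), compound 1 `COc1ccc(-c2ssc(=S)c2-c2cc(OC)c(OC)c(OC)c2)cc1` gives 4910 nM and compound 2 `COc1ccc(-c2ssc(=S)c2-c2cc(OC)c(OC)c(OC)c2)cc1O` gives 435 nM, the lower of the two numbers. Compound 3 `COc1ccc(-c2ssc(=S)c2-c2cc(OC)c(OC)c(OC)c2)cc1[N+](=O)[O-]` has nitro in place of hydroxy on an aromatic carbon, ortho to a methoxy group: nitro in place of hydroxy on an aromatic carbon. Among the measured compounds shown here, the one measured step bearing on this is an 11-fold lower number from compound 1 to compound 2 (1.05 log units; beyond the scatter), a large one, for hydroxy in place of hydrogen on that same carbon. For the measured compounds named here, no measured compound shows what nitro does there. With the hydroxy gone, a somewhat smaller move toward a higher number is expected in this assay. The expected step is a 5.7-fold higher number from compound 2 to compound 3 (0.76 log units; beyond the scatter). Compound 3 is estimated at 2500 nM, with an expected range of 600 nM to 10000 nM.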

Compound 3, half-maximal inhibitory concentration: > 100000 nM
Compound 3: no number, only a limit; the forecaster's own chance of this, stated with the estimate: 10%; at least 40-fold (1.60 log units) between middle value and limit.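

The value of compound 3 is a limit of the assay, not a number: the limit of > 100000 nM in this assay, at which 1 of the 3 values shown sits. Even so, replacing the hydroxy with nitro gives an at least 220-fold higher number from compound 2 to compound 3 (2.36 log units; beyond the scatter), and replacing the hydrogen of the parent with nitro gives an at least 20-fold higher number from compound 1 to compound 3 (1.30 log units; beyond the scatter). This carbon therefore does more than accept or lose a gain from hydroxy: in this assay, nitro falls beyond the hydrogen compound, so the three compounds run hydroxy, hydrogen, nitro from the lowest number to the highest.

From the compounds shown here alone, how far compound 3 lies past its limit stays open. Going by these compounds, whether an amine or a carboxylic acid on this carbon would follow hydroxy or nitro also stays open.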